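This account rests on a few compounds, and the source may have more. Where it says the series, first, only, none or still open, it means among the compounds named here.

Of the compounds shown here, three of the shared core have been measured in a functional assay on HeLa cells (Homo sapiens) for antiproliferative activity, read by CCK-8 assay, with a stated time of 72 h, tested at 2 uM; a higher number here means a stronger effect of the compound at the concentration tested, a lower number a weaker effect. Compound 1 `Nc1ccccc1NC(=O)c1ccc(CSC(=S)N2CCN(C(c3ccccc3)c3ccccc3)CC2)cc1` gives 8%, compound 2 `COc1ccc(N2CCN(C(=S)SCc3ccc(C(=O)Nc4ccccc4N)cc3)CC2)cc1` gives 39.4%, and compound 3 `Nc1ccccc1NC(=O)c1ccc(CSC(=S)N(Cc2ccccc2)Cc2ccccc2)cc1` gives 1%. Compound 2 therefore stands highest of the three numbers; its nearest neighbour is compound 1, whose number is lower by a gap beyond the scatter, and its furthest is compound 3, lower by a still larger gap that also exceeds the scatter. Going by the values given here, no single-point step between two measured compounds is available, so the behaviour of the aryl-bearing ring nitrogen cannot be read from a measured pair.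

Compound 4 `Nc1ccccc1NC(=O)c1ccc(CSC(=S)N2CCN(c3ccncc3)CC2)cc1` is not yet measured. It differs from compound 2 as follows: pyridin-4-yl in place of 4-methoxyphenyl on an amine nitrogen in a ring. Among the compounds with values here, with no measured step to lean on, the expected step from compound 2 to compound 4 in this assay is a modest decrease, a number 14.4 percentage points lower from compound 2 to compound 4 (beyond the scatter), though the data allow no firm direction. Compound 4 is estimated to give 25%, within a range from 5% to 50%.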

Compound 4, a percentage reported as inhibition, at one concentration (the size of the read-out at that concentration, not a potency): 77%
For compound 4 the middle estimate is 52 percentage points below the measured one; the whole stated range lies below it.
By their numbers in this assay, from the lowest: compounds 3 and 1 (each within the scatter of the next); then compound 2; then compound 4.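

In this assay the exchange of 4-methoxyphenyl for pyridin-4-yl on the amine nitrogen in the ring gives a number 37.6 percentage points higher from compound 2 to compound 4 (beyond the scatter) as a large step, which shows that the read-out at this position depends strongly on the identity of the aromatic group. The two groups each hold one six-membered aromatic ring and match in their hydrogen-bond donor and acceptor counts and in net charge, so the step comes with a change of ring atom and the loss of the methoxy group together, and the data cannot separate the two. No measurement of any property of these groups accompanies the step, so nothing here explains it.

Still open, going by these compounds, is whether pyridin-3-yl or pyridin-2-yl would match pyridin-4-yl here. Plain phenyl, which would separate the methoxy group from the ring nitrogen, also remains untested among the compounds shown.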